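The source may hold more compounds than are shown below. What is called first, only, known or untested is meant among the compounds shown, and "the series" means these compounds.

Of the compounds shown here, three carrying the same core have been measured in an assay for inhibition of 3-oxo-5-alpha-steroid 4-dehydrogenase 1 (Homo sapiens), tested at 10 uM; on this read-out lower numbers stand for less inhibition and higher numbers for more inhibition at the one concentration tested (going by the name of the read-out). Compound 1 `O=C(O)Cc1ccc(C=C2CCN(C(=O)C(C3CCCCC3)C3CCCCC3)CC2)c(F)c1` gives 4% in this assay. Compound 2 `O=C(O)c1cccc(C=C2CCN(C(=O)C(c3ccccc3)c3ccccc3)CC2)c1` gives 6% in this assay, and compound 3 `O=C(O)c1ccc(C=C2CCN(C(=O)CC(c3ccccc3)c3ccccc3)CC2)cc1` gives 8% in this assay. Compound 1 thus has the lowest of the three numbers, but the gap to compound 2 and the gap to compound 3 both lie within the scatter of repeated measurements, so the three compounds cannot be told apart on these numbers.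

The next compound, compound 4 `O=C(O)c1ccc(C=C2CCN(C(=O)C(C3CCCCC3)C3CCCCC3)CC2)cc1`, differs from compound 1 in one place: 4-carboxyphenyl in place of 4-(carboxymethyl)-2-fluorophenyl on a double-bonded chain carbon bound to a double-bonded ring carbon. Going by the values given here, no measured pair in this set shows the effect of this particular change, so its size can be judged only from the fact that every measured compound, across a cyclohexyl-bearing and two phenyl-bearing amides and differing carboxyl placements, returns a low number.

On that basis compound 4 is expected to behave like the others, with a step from compound 1 of a number 2 percentage points higher from compound 1 to compound 4 (within the scatter) that does not reach beyond the scatter. The estimate for compound 4 in this assay is 6%, in a range from 0% to 15%.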

Compound 4, a percentage reported as inhibition, at one concentration (the size of the read-out at that concentration, not a potency): 46%
Compound 4: the middle estimate sits 40 percentage points below what was measured, and the stated range ends below it.
By their numbers in this assay, from the lowest: compounds 1, 2 and 3 (each within the scatter of the next); then compound 4.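

The group on the double-bonded chain carbon bound to a double-bonded ring carbon proves decisive in this assay: exchanging 4-(carboxymethyl)-2-fluorophenyl for 4-carboxyphenyl gives a number 42 percentage points higher from compound 1 to compound 4 (beyond the scatter) and lifts the read-out well clear of the scatter, with the rest of the molecule unchanged. The earlier compounds shown here, whose numbers could not be told apart, gave no sign that a single exchange could move the read-out this far. Nothing available here accounts for the size of this step.

The exchange removes the fluorine and shortens the carboxymethyl group to a carboxyl in one move, so these compounds leave open which of the two differences carries the step, or whether both are needed. They also leave open how the read-out responds when the carboxylic acid at this position gives way to a tetrazole, a primary amide or an amine, and whether a longer chain would return it to the low numbers.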